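The compounds below may be only part of what the source reports. "The series", "measured", "known", "first", "only" and "open" are said of these compounds alone.

Measured so far:
- compound 1, `c1cc(-c2ccn[nH]2)c2c(c1)C(c1ncc[nH]1)CC2`: 83%
- compound 2, `Cn1ccc(-c2cccc3c2CCC3c2ncc[nH]2)n1`: 19%
- compound 3, `CS(=O)(=O)Nc1cccc2c1CCCC2c1ncc[nH]1`: 47%; 79%; 79% (3 entries)

In a functional assay on CHO cells for agonist activity at Alpha-1A adrenergic receptor (Homo sapiens), read by FLIPR and calcium flux (on this read-out higher numbers stand for larger maximal responses and lower numbers for smaller maximal responses), compound 1 gives the higher of the two single numbers; the nearest is compound 2, and the step of a number 64 percentage points lower from compound 1 to compound 2 (beyond the scatter) is large and beyond the scatter. Compound 3 has no single number; its repeated entries, (the several entries of compound 3 in this assay, 47%; 79%; 79% (3 entries)), show how far repeats of this kind can spread.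

Compound 4, `c1cc(-c2nccs2)c2c(c1)C(c1ncc[nH]1)CC2`, differs from compound 1 in one place: 1,3-thiazol-2-yl in place of 1H-pyrazol-5-yl on an aromatic carbon. Among the measured compounds shown here, the only measured step that bears on it, a number 64 percentage points lower from compound 1 to compound 2 (beyond the scatter), also exchanges the 1H-pyrazol-5-yl for another five-membered heteroaryl on the same aromatic carbon, and it lost most of the maximal response. The entering 1,3-thiazol-2-yl is a different ring, so the size is uncertain, but a drop is the expectation. The estimated step is a number 45 percentage points lower from compound 1 to compound 4 (beyond the scatter), and compound 4 is expected to give 38% in this assay, with a likely range from 12% to 70%.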

Compound 4, largest response reached (Emax), in percent of the reference or control that the assay uses: 64%
The estimate for compound 4 lay 26 percentage points below the measured number; the range from low to high includes it.
By their numbers in this assay, from the lowest: compound 2; then compound 4; then compound 1.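

At this aromatic carbon, the outcome in this assay depends on which five-membered ring enters, not only on the loss of the 1H-pyrazol-5-yl: the 1,3-thiazol-2-yl costs less (a number 19 percentage points lower from compound 1 to compound 4 (beyond the scatter)) than the 1-methyl-1H-pyrazol-3-yl did, and the two entering rings stand far apart (a number 45 percentage points higher from compound 2 to compound 4 (beyond the scatter)). The 1,3-thiazol-2-yl has 0 hydrogen-bond donors, so compound 4 shows that a substantial maximal response at this position does not require the donor of the 1H-pyrazol-5-yl. Repeats in this series can spread widely, which frames how finely these steps can be ranked: the several entries of compound 3 in this assay, 47%; 79%; 79% (3 entries).

On these data alone, whether an aromatic ring is needed on this carbon at all remains open, as an amine or a carboxylic acid there would test. Also open, as far as these compounds go, is whether the order of these rings carries over to the core of compound 3.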